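Aminopropylamino for methylsulfonyloxy on the shared core

The compounds below may be only part of what the source reports. "The series", "measured", "known", "first", "only" and "open" are said of these compounds alone.

Measured so far:
compound 1 `CS(=O)(=O)Oc1c(C(=O)NCc2ccc(F)cc2)nc(Br)c2cccnc12`: > 20000 nM
compound 2 `N[C@H]1CC[C@H](Nc2c(C(=O)NCc3ccccn3)nc(Br)c3cccnc23)CC1`: "not determined" (no result reported)
compound 3 `N[C@H]1CC[C@H](NC(=O)c2nc(Br)c3cccnc3c2NCc2ccc(F)cc2)CC1`: 6400 nM

In a functional assay on HCT-116 cells (Homo sapiens) for cytotoxicity, read by MTT assay, with a stated time of 72 h (on this read-out lower numbers stand for stronger inhibition and higher numbers for weaker inhibition), compound 1 sits at a limit of the assay, > 20000 nM, with no single number behind it. Compound 2 has no result in this assay. Among the measured compounds shown here, compound 3 is the one compound with a number here, giving 6400 nM. Where compound 1 stands is marked only by the limit of > 20000 nM in this assay, at which 1 of the 3 values shown sits, the weak end of what is shown.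

Compound 4 `NCCCNc1c(C(=O)NCc2ccc(F)cc2)nc(Br)c2cccnc12` differs from compound 1 by (3-aminopropyl)amino in place of (methylsulfonyl)oxy on an aromatic carbon. For the measured compounds named here, no step between two measured compounds is available, so the expectation rests on compound 3 and its 6400 nM. Compound 4 is expected to inhibit more strongly than compound 1, by a step of an at least 2.5-fold lower number from compound 1 to compound 4 (0.39 log units; beyond the scatter) beyond the usual scatter. The estimate for compound 4 is 8000 nM, between 2500 nM and 20000 nM.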

Compound 4, half-maximal inhibitory concentration: > 20000 nM
Compound 4 gave a limit, no number; the forecaster's own chance of this, stated with the estimate: 30%; at least 2.5-fold (0.39 log units) between middle value and limit.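

Compound 1 and compound 4 both sit at a limit, not a number, in this assay, so no step can be read between them. Going by these compounds, whether (3-aminopropyl)amino in place of (methylsulfonyl)oxy changes cytotoxicity on the shared core stays open.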